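Thiosemicarbazone series: methoxy added to the aryl ring

The source may hold more compounds than are shown below. What is called first, only, known or untested is meant among the compounds shown, and "the series" means these compounds.

Measured values in a functional assay on HT-29 cells (Homo sapiens) for inhibition, read by sulforhodamine B assay, with a stated time of 48 h; on this read-out lower numbers stand for stronger inhibition of growth and higher numbers for weaker inhibition of growth:
compound 1, `CC1=CC[C@H](C(C)(C)NC(=S)N/N=C/c2ccc(O)cc2)CC1`, > 100000 nM, a limit of the assay rather than a number
compound 2, `COc1cc(/C=N/NC(=S)NC(C)(C)[C@H]2CC=C(C)CC2)ccc1O`, < 40 nM, a limit of the assay rather than a number
compound 3, `CC1=CC[C@H](C(C)(C)NC(=S)N/N=C(\C)c2ccccc2)CC1`, 29500 nM

In this assay compound 1 sits at the limit of > 100000 nM in this assay, at which 1 of the 3 values shown sits. Compound 2 sits at the limit of < 40 nM in this assay, at which 1 of the 3 values shown sits. For the measured compounds named here, the single change between them, (methoxy in place of hydrogen on an aromatic carbon), gives an at least 2500-fold lower number from compound 1 to compound 2 (3.39 log units; beyond the scatter). Compound 3, with 29500 nM in this assay, is the only one of the three whose result is a number rather than a limit. The difference between the core of compound 1 and the core of compound 3 is not broken down here.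

Compound 4, `COc1ccc(/C(C)=N/NC(=S)NC(C)(C)[C@H]2CC=C(C)CC2)cc1`, is not yet measured in this assay. It differs from compound 3 by methoxy in place of hydrogen on an aromatic carbon. This is the same kind of change as that from compound 1 to compound 2, but not the same: in compound 2 the methoxy enters ortho to a hydroxy group and meta to a large group, whereas in compound 4 it enters para to a large group. The measured step between compound 1 and compound 2 is bounded on both sides by limits, so only its lower bound is known.

Compound 4 is expected to give 5000 nM in this assay, within 500 nM to 30000 nM. That expectation means a step of a 5.9-fold lower number from compound 3 to compound 4 (0.77 log units; beyond the scatter), resting on compound 3 at 29500 nM and on the large measured step from compound 1 to compound 2, scaled down by the difference in place.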

Compound 4, concentration for 50% growth inhibition: 18700 nM
Compound 4: middle estimate off by 3.7-fold (0.57 log units), on the low side; low and high end bracket the measured number.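

In this assay, methoxy in place of hydrogen on an aromatic carbon does not carry a single step size from one core to the other, and the two steps differ clearly: the same change on two cores in this assay, an at least 2500-fold lower number (3.39 log units; beyond the scatter) from compound 1 to compound 2 and a 1.6-fold lower number (0.20 log units; within the scatter) from compound 3 to compound 4, at least 1500-fold (3.19 log units) apart, beyond the scatter of two such steps. On the core of compound 3 the change gives a 1.6-fold lower number from compound 3 to compound 4 (0.20 log units; within the scatter), so the large step seen on the core of compound 1, an at least 2500-fold lower number from compound 1 to compound 2 (3.39 log units; beyond the scatter), cannot be applied as a fixed increment in this series. Going by these compounds, this does not show whether the gap belongs to the core or to the place of the methoxy, as the two pairs differ in both, and the size of the first step remains unknown beyond its bound, as both of its ends are limits of the assay.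

Still open, on these data alone, is what the same methoxy does on the core of compound 3 when it stands in the place it holds in compound 2, and with a hydroxy group on the same ring, which would separate the effect of place from that of the core. Also open, as far as these compounds go, is whether an ethoxy group or an amine at the position of the methoxy in compound 4 would give a step beyond the scatter.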